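The compounds below may be only part of what the source reports. "The series", "measured", "known", "first", "only" and "open" are said of these compounds alone.

Measured so far in an ADME assay (liver) for metabolic stability, with Liver microsome (Homo sapiens) as the target, read by LC-MS, using microsomes and NADPH, with a stated time of 5 min, at 37 degrees C; a lower number here means slower removal, a higher number faster removal of the compound
Compound 1 `CCn1c([C@@H](C)NS(=O)(=O)c2ccc(Cl)cc2)nc2ccc(OC)cc21` gives > 100 mL.min-1.g-1 as a limit
Compound 2 `CCn1c([C@@H](C)NS(=O)(=O)c2ccc(Cl)cc2)nc2ccc(C(F)(F)F)cc21` gives > 100 mL.min-1.g-1 as a limit
Compound 3 `CCn1c([C@@H](C)NS(=O)(=O)c2ccc(Cl)cc2)nc2ccc(S(C)(=O)=O)cc21` gives < 5 mL.min-1.g-1 as a limit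

Compound 2 stands at the limit of > 100 mL.min-1.g-1 in this assay, at which 2 of the 3 values shown sit, and so has a limit, not a number. The step of interest leads to compound 4 `CCn1c([C@@H](C)NS(=O)(=O)c2cccc(C#N)c2)nc2ccc(C(F)(F)F)cc21`, where 3-cyanophenyl takes the place of 4-chlorophenyl on a sulfonyl sulfur, with 3-cyanophenyl in place of 4-chlorophenyl on a sulfonyl sulfur as the count for this change. The measured steps are an at least 20-fold lower number from compound 2 to compound 3 (1.30 log units; beyond the scatter) and an at least 20-fold lower number from compound 1 to compound 3 (1.30 log units; beyond the scatter) as two large ones, plus a step that the two limits leave unreadable from compound 1 to compound 2 as one of unreadable size. All three change a group on an aromatic carbon and none changes the group on the sulfonyl sulfur, so they give no direct size for this change. Compound 4 keeps the trifluoromethyl of compound 2, so the large steps to compound 3 are not expected to carry over. The expectation therefore starts from compound 2 with its limit of > 100 mL.min-1.g-1 as the anchor. In this assay only a modest move toward a lower number is expected, and the expected step is an at least 1.4-fold lower number from compound 2 to compound 4 (0.15 log units; that floor lies within the scatter) in all. For compound 4 the estimated value is 70 mL.min-1.g-1 with an expected range from 20 mL.min-1.g-1 to 200 mL.min-1.g-1 overall.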

Compound 4, intrinsic clearance in microsomes: > 100 mL.min-1.g-1
Compound 4 gave a limit, no number; the forecaster's own chance of this, stated with the estimate: 40%; middle value at least 1.4-fold (0.15 log units) away from the limit.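

In this assay compound 4 gives > 100 mL.min-1.g-1, a limit and not a number. Compound 2 also stands at a limit, so no step can be read between compound 2 and compound 4. The compounds shown leave open how far 3-cyanophenyl in place of 4-chlorophenyl on a sulfonyl sulfur moves the clearance, if at all.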